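Diphosphate removal and a methoxy swap in a nucleotide series

The source may report more compounds than this note shows. Statements on the series, on what has been measured and on what is new or still open speak of the compounds shown alone.

Measured so far:
compound 1 `Nc1nc(=O)ccn1[C@@H]1O[C@H](COP(=O)(O)OP(=O)(O)O)[C@@H](O)[C@H]1O` – >= 100000 nM
compound 2 `Nc1nc(=O)ccn1[C@@H]1O[C@H](COP(=O)(O)O)[C@@H](O)[C@H]1O` – 4980 nM

In an in vitro functional assay on 1321-N1 cells for agonist activity at P2Y purinoceptor 4 (Homo sapiens), read by scintillation proximity assay and inositol phosphate accumulation (on this read-out lower numbers stand for an effect already at smaller amounts and higher numbers for an effect only at larger amounts of compound), compound 1 returns only a limit, (the limit of >= 100000 nM in this assay, at which 1 of the 2 values shown sits). In this assay compound 2 gives 4980 nM, the only number shown. Going by the values given here, the one measured step, an at least 20-fold lower number from compound 1 to compound 2 (1.30 log units; beyond the scatter), is a hydrogen atom in place of a group of 4 heavy atoms on an oxygen.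

Compound 3 `COc1nc(=O)ccn1[C@@H]1O[C@H](COP(=O)(O)O)[C@@H](O)[C@H]1O` is not yet measured. Against compound 2 it shows (methoxy in place of amino on an aromatic carbon). Among the compounds with values here, no measured step touches this position; the step from compound 1 to compound 2 concerns a different part of the shared core and gives no guide to the size or direction of this change. With a donor lost, a movement toward larger numbers is thought more likely than the reverse, but the uncertainty is wide.

The estimate for compound 3 in this assay is 12000 nM, with a range from 2500 nM to 60000 nM. This estimate corresponds to an expected step of a 2.4-fold higher number from compound 2 to compound 3 (0.38 log units; beyond the scatter).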

Compound 3, half-maximal effective concentration: > 100000 nM
Compound 3: only a limit was reported; the forecaster's own chance of this, stated with the estimate: 30%; at least 8.3-fold (0.92 log units) between middle value and limit.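

Working notes: the aromatic carbon between two ring nitrogen atoms proves sensitive to substitution, with methoxy in place of amino giving an at least 20-fold higher number from compound 2 to compound 3 (1.30 log units; beyond the scatter) in this assay. Compound 3 returns a limit of the assay and not a number: the limit of > 100000 nM in this assay, at which 1 of the 3 values shown sits.

Going by these compounds alone, the earlier step concerned a different part of the shared core, so this is the first sign that the amino position also matters in this assay, and that methoxy does not serve as a replacement for amino there.

The swap changes the hydrogen-bond donor count and the heavy-atom count together, and these two compounds cannot separate the two changes. From the compounds shown here alone, how a methylamino, dimethylamino or hydroxyl group would read at this position stays open, as does the full size of the step beyond the limit.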